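Swapping the Indanyl Group on a Fluorinated Core

The source may hold more compounds than are shown below. What is called first, only, known or untested is meant among the compounds shown, and "the series" means these compounds.

Measured so far in an assay on BaF3 cells for inhibition of thrombopoietin receptor (Homo sapiens), tested at 300 nM; a higher number here means a stronger effect of the compound at the concentration tested, a lower number a weaker effect:
- compound 1 `C/C(NNC(=S)N1CCc2cc(C(=O)O)ccc21)=C1/C(=O)N(c2ccc3c(c2)CCC3)c2ccccc21` gives 75.8%
- compound 2 `C/C(NNC(=S)N1CCc2cc(C(=O)O)ccc21)=C1/C(=O)N(c2ccc(C)c(C)c2)c2ccccc21` gives 138%
- compound 3 `C/C(NNC(=S)N1CCc2cc(C(=O)O)ccc21)=C1/C(=O)N(c2ccc3c(c2)CCC3)c2ccc(F)cc21` gives 10.6%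

Compound 3 stands lowest of the three numbers. Its nearest neighbour is compound 1, where fluoro in place of hydrogen on an aromatic carbon gave a number 65.2 percentage points lower from compound 1 to compound 3 (beyond the scatter); compound 2 lies furthest away.

The step to compound 4 `C/C(NNC(=S)N1CCc2cc(C(=O)O)ccc21)=C1/C(=O)N(c2ccc(C)cc2)c2ccc(F)cc21` changes the substituent on the amide-type nitrogen in the ring: 4-methylphenyl in place of 2,3-dihydro-1H-inden-5-yl on an amide-type nitrogen in a ring.

For the measured compounds named here, the measured step that bears on this is the one between compound 1 and compound 2, where 3,4-dimethylphenyl replaced 2,3-dihydro-1H-inden-5-yl at the same place on the core without fluoro: a number 62.2 percentage points higher from compound 1 to compound 2 (beyond the scatter). There the 2,3-dihydro-1H-inden-5-yl group was the weaker of the two. Compound 4 carries 4-methylphenyl rather than 3,4-dimethylphenyl, and its core also carries the fluoro that lowered the number from compound 1 to compound 3, so a repeat of the full rise is not assured. Still, a rise beyond the scatter is expected for compound 4, about a number 34.4 percentage points higher from compound 3 to compound 4 (beyond the scatter) in this assay. Compound 4 is therefore estimated at 45%, within a range of 15% to 85%.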

Compound 4, a percentage reported as inhibition, at one concentration (the size of the read-out at that concentration, not a potency): 122%
For compound 4 the middle estimate is 77 percentage points below the measured one; measured number above the stated range.
By their numbers in this assay, from the lowest: compound 3; then compound 1; then compound 4; then compound 2.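

In this assay the change to 4-methylphenyl gives a number 111.4 percentage points higher from compound 3 to compound 4 (beyond the scatter) and so shows that the group on the amide-type nitrogen in the ring has a large influence on the fluoro-bearing core too. On the core without fluoro, a different replacement of 2,3-dihydro-1H-inden-5-yl gave a rise in the same direction (a number 62.2 percentage points higher from compound 1 to compound 2 (beyond the scatter)), so these two pairs agree, though the entering groups are not the same. Compound 3 carries the fluoro and its reading is low. In this assay compound 4 keeps that fluoro and reaches 122%.

Still open, from the compounds shown here alone, is whether a 4-ethylphenyl or a 4-methoxyphenyl group on this nitrogen would hold the number as high, and how much the fluoro matters when 4-methylphenyl is the group in place. Nothing available here gives an independent measurement that explains the size of this step.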